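Cyclopentyl for methoxyphenyl on the pyrrole-type nitrogen

The source may report more compounds than this note shows. Statements on the series, on what has been measured and on what is new or still open speak of the compounds shown alone.

Three compounds of the series have numbers in an assay on HEK293 cells for displacement of a labelled ligand from melanin-concentrating hormone receptor 1 (Homo sapiens); on this read-out higher numbers stand for weaker inhibition and lower numbers for stronger inhibition. Compound 1 `O=C(NC1CCN(Cc2ccc(Cl)c(Cl)c2)CC1)c1csc([N+](=O)[O-])c1` gives 92 nM in this assay. Compound 2 `O=C(COc1cccc(Cl)c1)NC1CCN(Cc2ccc3ccccc3c2)CC1` gives 41 nM. Compound 3 `COc1ccc(-n2ccc(CN3CCC(NC(=O)COc4cccc(Cl)c4)CC3)c2)cc1` gives 100 nM, the highest of the three numbers; its gap to compound 1 lies within the usual scatter, so no order between those two is claimed, while its gap to compound 2 lies beyond the scatter.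

Compound 4 `O=C(COc1cccc(Cl)c1)NC1CCN(Cc2ccn(C3CCCC3)c2)CC1` has not been measured. It differs from compound 3 in one place: cyclopentyl in place of 4-methoxyphenyl on an aromatic nitrogen, two ring bonds from the ring atom that bears a large group. Within the data shown here, no pair of measured compounds shows this change, so there is no measured step to lean on. The expectation is a step of no clear direction and of a size within the scatter, a 1.2-fold higher number from compound 3 to compound 4 (0.08 log units; within the scatter). Compound 4 is therefore estimated at 120 nM, with a range from 40 nM to 400 nM.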

Compound 4, half-maximal inhibitory concentration: > 33000 nM
Compound 4: no number, only a limit (the forecaster's own chance of this, stated with the estimate: 5%); at least 270-fold (2.43 log units) between middle value and limit.
By their numbers in this assay, from the lowest: compound 2; then compounds 1 and 3 (each within the scatter of the next). At a limit, above all of these: compound 4.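

On an aromatic nitrogen of the five-membered aromatic ring, the group proves decisive: in this assay, cyclopentyl in place of 4-methoxyphenyl gives an at least 330-fold higher number from compound 3 to compound 4 (2.51 log units; beyond the scatter). Compound 4 stands at a limit of the assay and not at a number: the limit of > 33000 nM in this assay, at which 1 of the 4 values shown sits. Among these compounds, this is the first single-place comparison, and it shows that this position does not tolerate every ring: a five-membered non-aromatic ring of carbon only does not stand in for 4-methoxyphenyl here.

The compounds shown leave open which part of 4-methoxyphenyl carries the difference, the methoxy group or the six-membered aromatic ring itself. Plain phenyl or cyclohexyl on the same nitrogen would separate the two, and whether the step holds with other groups on the rest of the core remains unknown.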